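Swapping Chloro for Iodo on a Nucleoside Transporter Inhibitor

The compounds below may be only part of what the source reports. "The series", "measured", "known", "first", "only" and "open" are said of these compounds alone.

Compound 1, `CNc1nc(SCc2ccc([N+](=O)[O-])cc2)c2ncn([C@@H]3O[C@H](CO)[C@@H](O)[C@H]3O)c2n1`: 24 nM
Compound 2, `O=[N+]([O-])c1ccc(CSc2nc(Cl)nc3c2ncn3[C@@H]2O[C@H](CO)[C@@H](O)[C@H]2O)cc1`: 11 nM

Both compounds were tested in an assay on K562 cells for displacement of a labelled ligand from Equilibrative nucleoside transporter 1 (Homo sapiens), read by flow cytometry, with a stated time of 45 min; on this read-out higher numbers stand for weaker inhibition and lower numbers for stronger inhibition. Compound 1 gives 24 nM in this assay, and compound 2 gives 11 nM. For the measured compounds named here, the one measured step, a 2.2-fold lower number from compound 1 to compound 2 (0.34 log units; beyond the scatter), shows that replacing the methylamino group with chloro on the shared core moved the number downward. Going by the values given here, with only two numbers in hand, compound 2 stands as the lower of the two, its nearest neighbour being compound 1.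

Compound 3, `O=[N+]([O-])c1ccc(CSc2nc(I)nc3c2ncn3[C@@H]2O[C@H](CO)[C@@H](O)[C@H]2O)cc1`, is not yet measured. It differs from compound 2 in a single place: iodo in place of chloro on an aromatic carbon. Among the compounds with values here, no measured step bears on exchanging one halogen for another at this carbon; the only step available, from compound 1 to compound 2, concerns a methylamino group leaving and chloro entering, which is a different kind of change. Without a comparable precedent, the expectation is a step of a 1.1-fold lower number from compound 2 to compound 3 (0.04 log units; within the scatter), that is, none beyond the scatter. Compound 3 is therefore estimated at 10 nM in this assay, with a range from 4 nM to 30 nM.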

Compound 3, inhibition constant: 11 nM
Compound 3: the middle estimate sits 1.1-fold (0.04 log units) below what was measured; the measured number falls inside the stated range.
By their numbers in this assay, from the lowest: compounds 2 and 3 (each within the scatter of the next); then compound 1.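

In this assay, exchanging chloro for iodo at this carbon, which lies between two ring nitrogen atoms, gives no change at the digits printed from compound 2 to compound 3 (within the scatter), so the two halogens cannot be told apart at this position. Iodo in place of methylamino gives a 2.2-fold lower number from compound 1 to compound 3 (0.34 log units; beyond the scatter), so the lower number seen on leaving methylamino is no longer tied to chloro alone: it appears with both halogens shown. The data here offer no explanation of why the two halogens read alike, or why either reads lower than methylamino.

Only chloro, iodo and methylamino are shown at this carbon, so it remains open how a plain amine, a methoxy group or a longer alkyl chain would read there, and whether any of them would fall in line with the halogens or with methylamino. As far as these compounds go, all three compounds also share the nitro group on the benzyl ring, so it remains open whether the exchange of chloro for iodo would still read the same with an amine or a carboxylic acid in its place.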